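The source may hold more compounds than are shown below. What is called first, only, known or untested is meant among the compounds shown, and "the series" means these compounds.

Compound 1 `COc1cc2cc(Oc3ccc(NC(=O)Nc4ccccc4)cc3)c(C)nc2cc1OC` and compound 2 `COc1cc2cc(Oc3ccc(NC(=O)Nc4ccc(C(F)(F)F)cc4)cc3)c(C)nc2cc1OC` share one core and differ only at the far end. In a functional assay on 786-0 cells (Homo sapiens) for inhibition, read by sulforhodamine B assay, with a stated time of 48 h, tested at 10 uM (a lower number here means a stronger effect, a higher number a weaker effect of the compound at the concentration tested), compound 1 gives 94.8%, while compound 2 gives 74.9%, the lowest of the two numbers. That single step, a number 19.9 percentage points lower from compound 1 to compound 2 (beyond the scatter), came from a trifluoromethyl in place of hydrogen on an aromatic carbon. Compound 3 `COc1cc2cc(Oc3ccc(NC(=O)Nc4cccc(C(F)(F)F)c4)cc3)c(C)nc2cc1OC` keeps every atom but moves the group: 3-(trifluoromethyl)phenyl in place of 4-(trifluoromethyl)phenyl on an amide-type nitrogen. Going by the values given here, no measured step shows what moving the group does, so little beyond the scatter is expected; the expected step of a number 1.1 percentage points higher from compound 2 to compound 3 (within the scatter) is small. Compound 3 is estimated at 76%, likely between 55% and 95%.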

Compound 3, a percentage reported as activity, at one concentration (the size of the read-out at that concentration, not a potency): 15.1%
For compound 3 the middle estimate is 60.9 percentage points above the measured one; measured number outside the range, below it.
By their numbers in this assay, from the lowest: compound 3; then compound 2; then compound 1.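

In this assay, the position of the trifluoromethyl group matters a great deal: 3-(trifluoromethyl)phenyl in place of 4-(trifluoromethyl)phenyl on the amide-type nitrogen gives a number 59.8 percentage points lower from compound 2 to compound 3 (beyond the scatter). Adding the group in this new placement gives a number 79.7 percentage points lower from compound 1 to compound 3 (beyond the scatter), so its effect cannot be read from its presence alone. Nothing available here explains why the placement counts for so much. On these data alone, whether a chlorine atom or a methoxy group in place of the trifluoromethyl of compound 3 would keep the strong effect remains open.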